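The source may report more compounds than this note shows. Statements on the series, on what has been measured and on what is new or still open speak of the compounds shown alone.

Measured compounds:
compound 1, `CCCC1=C(OC)C(CCC)(CCC)C(=O)/C(=C(O)\C=C\c2ccccc2)C1=O`, in a functional assay on PC-3 cells (Homo sapiens) for antiproliferative activity, read by sulforhodamine B assay, with a stated time of 3 days (a higher number here means that more compound is needed for the effect, a lower number that less compound is needed), compound 1 gives 8.2 uM
compound 2, `COC1=C(CC(C)C)C(=O)/C(=C(O)/C=C/c2ccccc2)C(=O)C1(CC(C)C)CC(C)C`, in this assay compound 2 gives 12.4 uM

The gap between compound 1 and compound 2 lies within the usual scatter of this assay, so the two cannot be set apart; compound 1 simply serves as the starting point for the next step. Compound 3, `CCCCOC1=C(CCC)C(=O)/C(=C(O)/C=C/c2ccccc2)C(=O)C1(CCC)CCC`, is the unmeasured analogue. It differs from compound 1 by propyl in place of hydrogen on a saturated chain carbon bound to an oxygen on an unsaturated carbon, a change on the alkoxy group of the shared core while everything else stays fixed.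

Within the data shown here, no step between measured compounds touches this position, so there is nothing in the data to size the change from; the expectation rests only on the value of compound 1. The step from compound 1 to compound 3 is expected to be small, a 1.0-fold higher number from compound 1 to compound 3 (0.02 log units; within the scatter), in no firm direction beyond the scatter. Compound 3 is therefore estimated at 8.5 uM in this assay, with a range of 3.5 uM to 20 uM.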

Compound 3, concentration for half-maximal effect: 9.6 uM
Beside the measured number, compound 3's estimate is 1.1-fold (0.05 log units) below it; the measured number falls inside the stated range.
By their numbers in this assay, from the lowest: compounds 1, 3 and 2 (each within the scatter of the next).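

Methoxy to butoxy, which is propyl in place of hydrogen on a saturated chain carbon bound to an oxygen on an unsaturated carbon, gives a 1.2-fold higher number from compound 1 to compound 3 (0.07 log units; within the scatter) in this assay and is the only step read at this position. On this one pair, the alkoxy group of the shared core carries a butyl chain in place of a methyl with no difference that can be told from the scatter, so the two compounds cannot be set apart. No measured property or other supporting information bears on this result.

As far as these compounds go, whether the same holds beyond plain alkyl chains stays open, for example with an amine or a carboxylic acid at the end of the butoxy chain. A longer chain such as octyloxy, or a benzyloxy group, also remains to be placed against compound 1 at this position.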